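Removing a Methoxy From a Porcupine Inhibitor Series

The source may hold more compounds than are shown below. What is called first, only, known or untested is meant among the compounds shown, and "the series" means these compounds.

Among the measured compounds shown here, compound 2 `COc1ccc2nc(NC(=O)CNC(=O)c3nn(-c4ccccc4OC)c(=O)c4ccccc34)sc2c1` is one of two compounds so far measured in an assay on L cells for inhibition of Protein-serine O-palmitoleoyltransferase porcupine (Mus musculus), read by reporter gene assay, with a stated time of 24 h; a lower number here means that less compound is needed, a higher number that more compound is needed for the effect; here compound 2 gives 90 nM. For the measured compounds named here, compound 1 `Cc1ccc2nc(NC(=O)CNC(=O)c3nn(-c4ccccc4)c(=O)c4ccccc34)sc2c1` is the only other compound with a number, and in this assay compound 1 gives 35 nM. Of the two numbers, that of compound 2 is the higher, and its gap to compound 1 lies beyond the scatter of repeated runs. The two compounds differ in more than one place, so their two values can only be set side by side and no single step can be read from them.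

Compound 3 `COc1ccccc1-n1nc(C(=O)NCC(=O)Nc2nc3ccccc3s2)c2ccccc2c1=O` has not yet been measured. It differs from compound 2 in one place: hydrogen in place of methoxy on an aromatic carbon. In words, a hydrogen takes the place of a methoxy on an aromatic carbon. Going by the values given here, no measured pair in this small set isolates this change, so its direction cannot be read from the numbers in hand. Compound 3 is expected to shift only modestly, by a 1.3-fold lower number from compound 2 to compound 3 (0.11 log units; within the scatter), with no firm direction beyond the scatter. Compound 3 is therefore estimated at 70 nM in this assay, within 30 nM to 180 nM.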

Compound 3, half-maximal effective concentration: 10000 nM
Compound 3: middle estimate off by 140-fold (2.15 log units), on the low side; measured number outside the range, above it.
By their numbers in this assay, from the lowest: compound 1; then compound 2; then compound 3.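

Replacing the methoxy of the 6-methoxy-1,3-benzothiazol-2-yl group with hydrogen is far from a neutral edit: in this assay it gives a 110-fold higher number from compound 2 to compound 3 (2.05 log units; beyond the scatter) and so marks this aromatic carbon as a highly sensitive place in the series. The earlier compounds shown here could not show this, as they differ from each other in more than one place, whereas here the rest of compound 2 stays unchanged and the whole step goes with the loss of two heavy atoms, one carbon and one oxygen. Nothing available on these compounds accounts for a step of this size.

As far as these compounds go, it remains open whether the number depends on the methoxy itself, or whether a chlorine atom, an amine or an ethoxy group on the same aromatic carbon would keep it near that of compound 2. What the second methoxy, which compound 3 retains, contributes is also unresolved, and no pair among these compounds isolates it.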